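Cytotoxicity of Two Benzoxaborole Pyrroles and a Planned Analogue

The source may report more compounds than this note shows. Statements on the series, on what has been measured and on what is new or still open speak of the compounds shown alone.

Compound 1: `O=C(O)c1cccn1-c1ccc2c(c1)B(O)OC2` — > 10 ug/mL
Compound 2: `O=C(c1cccc(Cl)c1)c1ccn(-c2ccc3c(c2)B(O)OC3)c1` — > 10 ug/mL

In an ADME assay on L929 cells (Mus musculus) for cytotoxicity, read by resazurin assay, with a stated time of 72 h (on this read-out higher numbers stand for weaker inhibition and lower numbers for stronger inhibition), compound 1 gives > 10 ug/mL, which is a limit of the assay rather than a number. In this assay compound 2 likewise gives > 10 ug/mL, again a limit and not a number. Compound 2 thus stands at the limit of > 10 ug/mL in this assay, at which 2 of the 2 values shown sit. Compound 3, `Nc1ccc(C(=O)c2ccn(-c3ccc4c(c3)B(O)OC4)c2)cc1`, differs from compound 2 by 4-aminophenyl in place of 3-chlorophenyl on a carbonyl carbon. For the measured compounds named here, with no measured step to draw on, only a small change is expected in this assay, none beyond the usual scatter, as a step that the limit leaves unreadable from compound 2 to compound 3. Compound 3 is therefore estimated at 20 ug/mL, with a likely range from 8 ug/mL to 60 ug/mL.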

Compound 3, half-maximal inhibitory concentration: 3.9 ug/mL
Estimate against measurement, compound 3: 5.1-fold (0.71 log units) above; the whole stated range lies above it.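

In this assay, 4-aminophenyl in place of 3-chlorophenyl on a carbonyl carbon gives an at least 2.5-fold lower number from compound 2 to compound 3 (0.40 log units; beyond the scatter), so this position can shift the read-out towards stronger inhibition of the cells. Compound 3 is the only compound shown with a real number, while the others sit at a limit: the limit of > 10 ug/mL in this assay, at which 2 of the 3 values shown sit. Going by these compounds, the full size of the step stays unknown, since only a limit is available for compound 2. On these data alone, whether a hydroxyl or a methoxy group in place of the amine would have the same effect remains open.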